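Piperazin-1-yl for dimethylamino on the side chain

The compounds below may be only part of what the source reports. "The series", "measured", "known", "first", "only" and "open" are said of these compounds alone.

In an ADME assay on MT4 cells (Homo sapiens) for cytotoxicity, read by MTT assay, with a stated time of 5 days (a lower number here means that less compound is tolerated, a higher number that more compound is tolerated), compound 1 `Cc1cc(/C=C/C#N)cc(C)c1Oc1cc(NCCN(C)C)nc(Nc2ccc(C#N)cc2)n1` gives 3040 nM and compound 2 `Cc1cc(/C=C/C#N)cc(C)c1Oc1cc(NCCN(C)C)nc(Nc2ccc(C#N)cc2)c1` gives 4270 nM as its number, two values within the scatter of each other. Compound 3 `C=CCNc1cc(Oc2c(C)cc(/C=C/C#N)cc2C)cc(Nc2ccc(C#N)cc2)n1` gives a far larger 82100 nM by comparison, so compound 1 sits at the low end of the numbers, level with compound 2.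

Compound 4 `Cc1cc(/C=C/C#N)cc(C)c1Oc1cc(NCCN2CCNCC2)nc(Nc2ccc(C#N)cc2)n1` differs from compound 1 in one place (piperazin-1-yl in place of dimethylamino on a saturated chain carbon, two bonds along the chain from a nitrogen on an aromatic ring): piperazin-1-yl stands in place of dimethylamino on a saturated chain carbon, two bonds along the chain from a nitrogen on an aromatic ring.

Among the compounds with values here, the one measured step that bears on this is a 19-fold higher number from compound 2 to compound 3 (1.28 log units; beyond the scatter) and it is large, with vinyl in place of (dimethylamino)methyl. Compound 3 at 82100 nM has no nitrogen in the group that enters, whereas compound 4 keeps nitrogen there, so a much smaller step is expected in this assay with a slight rise at most. The expected move is a 1.3-fold higher number from compound 1 to compound 4 (0.12 log units; within the scatter) and possibly none beyond the scatter. Compound 4 is estimated at 4000 nM with an expected range of 1300 nM to 15000 nM in this read-out.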

Compound 4, half-maximal cytotoxic concentration: 3650 nM
Compound 4: the middle estimate sits 1.1-fold (0.04 log units) above what was measured, and the stated range covers the measured number.
By their numbers in this assay, from the lowest: compounds 1, 4 and 2 (each within the scatter of the next); then compound 3.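

In this assay, a 1.2-fold higher number from compound 1 to compound 4 (0.08 log units; within the scatter), so the number does not separate piperazin-1-yl from dimethylamino at this place on the chain. The entering group is larger and brings a six-membered ring and a hydrogen-bond donor, yet this one step shows no difference in tolerated concentration beyond the usual scatter. Within the data shown here, the earlier large step, a 19-fold higher number from compound 2 to compound 3 (1.28 log units; beyond the scatter), came from a swap to vinyl on a different core, while this swap from one amine to another gives the first reading on the core of compound 1. No supporting measurement is available to explain this result.

On these data alone, whether a morpholin-4-yl group or a carboxylic acid at the chain end would give a similar number remains open. So does the effect of a longer chain between the ring nitrogen and the piperazin-1-yl group.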